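This account rests on a few compounds, and the source may have more. Where it says the series, first, only, none or still open, it means among the compounds named here.

Working notes on the series in a functional assay on PANC-1 cells (Homo sapiens) for cytotoxicity, read by WST assay, with a stated time of 24 h; a lower number here means a stronger inhibitor, a higher number a weaker inhibitor. Compound 1 (`O=C(CCCCCCCCc1ccccc1)N1CCCCC1`) reads > 100000 nM, which is a limit of the assay and not a number. Compound 2 (`Cc1ccc(CCCCCCCCC(=O)N2CCCCC2)cc1`) reads > 100000 nM, also a limit. For the measured compounds named here, compound 3 (`COc1ccc(CCCCCCCCC(=O)N2CCCCC2)cc1`) gives 89300 nM, the only actual number in the set. The other two readings stand at the limit of > 100000 nM in this assay, at which 2 of the 3 values shown sit.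

Compound 4 (`O=C(CCCCCCCCc1ccccc1Cl)N1CCCCC1`) has not yet been measured. Its structure differs as follows: 2-chlorophenyl in place of 4-methoxyphenyl on a saturated chain carbon, eight bonds along the chain from a carbonyl carbon. The group change is 2-chlorophenyl in place of 4-methoxyphenyl.

Going by the values given here, three measured steps bear on this only indirectly, as none of them involves a 2-chlorophenyl group. Methyl in place of hydrogen gives a step that the two limits leave unreadable from compound 1 to compound 2. Methoxy in place of hydrogen gives an at least 1.1-fold lower number from compound 1 to compound 3 (0.04 log units; that floor lies within the scatter). Methoxy in place of methyl gives an at least 1.1-fold lower number from compound 2 to compound 3 (0.04 log units; that floor lies within the scatter). No step in the set is therefore shown to lie beyond the scatter, and none beyond the scatter is expected in this assay. A reading at the limit is about as likely as a number.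

For compound 4 the expected step is a 1.1-fold higher number from compound 3 to compound 4 (0.03 log units; within the scatter). The estimate for compound 4 is 95000 nM, with an expected range from 45000 nM to 190000 nM.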

Compound 4, half-maximal inhibitory concentration: > 100000 nM
Compound 4 was reported as a limit; the forecaster's own chance of this, stated with the estimate: 55%; middle value at least 1.0-fold (0.02 log units) away from the limit.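

In this assay compound 4 reads > 100000 nM, which is a limit of the assay and not a number. On a saturated chain carbon, eight bonds along the chain from a carbonyl carbon, 2-chlorophenyl in place of 4-methoxyphenyl gives an at least 1.1-fold higher number from compound 3 to compound 4 (0.04 log units; that floor lies within the scatter), so this change is not shown to move the reading beyond the scatter, and the steps from compound 1 and from compound 2 to compound 4 cannot be read, as both ends of each are limits. At this place 2-chlorophenyl thus joins phenyl and 4-methylphenyl among the groups that give no number, and compound 3 stays the only compound in the set that has one, the rest sitting together at the top of the range: the limit of > 100000 nM in this assay, at which 3 of the 4 values shown sit.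

How far compound 1, compound 2 and compound 4 lie from compound 3, or from each other, stays open, and no step in the set is shown to lie beyond the scatter. Also open, as far as these compounds go, is whether any reading clearly lower than that of compound 3 can be reached, for instance with an amine or a carboxylic acid on the aromatic ring, or with a longer chain.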